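A few compounds are considered here, and "the series" means these few. Any claim that something is new, unique, unknown or untested is made for them only; others in the source may bear on it.

Measured in a physicochemical assay for solubility; on this read-out higher numbers stand for higher solubility and lower numbers for lower solubility:
- Compound 1 `CNC(=O)c1cc(C(=O)N[C@H]2[C@@H]3C[C@@H](OC)C[C@@H]32)n([C@@H](C)c2ccccc2)n1`: >= 150 ug/mL
- Compound 2 `CNC(=O)c1cc(C(=O)NCCO)n([C@@H](C)c2ccccc2)n1`: >= 139 ug/mL
- Compound 3 `CNC(=O)c1cc(C(=O)NC(C)CO)n([C@@H](C)c2ccccc2)n1`: >= 132 ug/mL

Each of these three entries is a limit, not a number. Compound 3 therefore stands only at its limit of >= 132 ug/mL.

Compound 4 `CNC(=O)c1cc(C(=O)N[C@H]2[C@@H]3C[C@@H](O)C[C@@H]32)n([C@@H](C)c2ccccc2)n1` differs from compound 3 on an amide-type nitrogen: a group of 7 heavy atoms (6 carbon, 1 oxygen; one three-membered non-aromatic ring of carbon only, one five-membered non-aromatic ring of carbon only) in place of a group of 4 heavy atoms (3 carbon, 1 oxygen; no ring), on an amide-type nitrogen.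

Among the compounds with values here, the steps that bear on this change are a step that the two limits leave unreadable from compound 1 to compound 3 and a step that the two limits leave unreadable from compound 1 to compound 2, so neither offers a size to carry over. Compound 1, whose group has the same two ring types, also gives only a limit, >= 150 ug/mL.

In this assay, the expected step is a step that the limit leaves unreadable from compound 3 to compound 4, with nothing expected beyond the scatter. Compound 4 is estimated at 145 ug/mL, within an expected range of 85 ug/mL to 190 ug/mL.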

Compound 4, solubility: >= 291 ug/mL
Compound 4 was reported as a limit; the forecaster's own chance of this, stated with the estimate: 80%; middle value at least 2.0-fold (0.30 log units) away from the limit.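

In this assay, within the data shown here, compound 4 is reported only as a limit, as are compound 1, compound 2 and compound 3, so no step to compound 4 can be read. The compounds shown leave open the actual value of each of the four and their order.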